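Aryl urea variation in the SMMC-7721 series: compound 4

The compounds below may be only part of what the source reports. "The series", "measured", "known", "first", "only" and "open" are said of these compounds alone.

Measured so far:
compound 1, `Nc1n[nH]c2cccc(-c3cccc(NC(=O)Nc4cccc(Cl)c4)c3)c12`, 1830 nM
compound 2, `Nc1n[nH]c2cccc(-c3cccc(NC(=O)Nc4cc(C(F)(F)F)cc(C(F)(F)F)c4)c3)c12`, 3540 nM
compound 3, `Cc1ccc(NC(=O)Nc2cccc(-c3cccc4[nH]nc(N)c34)c2)cc1`, 4450 nM

In a functional assay on SMMC-7721 cells (Homo sapiens) for inhibition, read by MTT assay, with a stated time of 48 h (a higher number here means a weaker inhibitor, a lower number a stronger inhibitor), compound 3 gives the highest of the three numbers; its gap to compound 2 lies within the scatter, its gap to compound 1 beyond it. Within the data shown here, the only single-point step measured is a 2.4-fold higher number from compound 1 to compound 3 (0.39 log units; beyond the scatter). Compound 4, `Nc1n[nH]c2cccc(-c3cccc(NC(=O)Nc4cccc(C(F)(F)F)c4)c3)c12`, differs from compound 3 by 3-(trifluoromethyl)phenyl in place of 4-methylphenyl on an amide-type nitrogen. Among the measured compounds shown here, this step has no direct precedent, but it reinstates a substituted phenyl on the urea of the kind seen in compound 1 and compound 2, both of which sit at lower numbers than compound 3. A modest move toward those values is therefore expected, a 1.9-fold lower number from compound 3 to compound 4 (0.29 log units; within the scatter). For compound 4 in this assay the estimate is 2300 nM, with a range of 1000 nM to 5000 nM.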

Compound 4, half-maximal inhibitory concentration: 1410 nM
Beside the measured number, compound 4's estimate is 1.6-fold (0.21 log units) above it; low and high end bracket the measured number.
By their numbers in this assay, from the lowest: compounds 4, 1, 2 and 3 (each within the scatter of the next, the first and the last beyond it).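

In this assay, the aryl group on the amide-type nitrogen now gives steps beyond the scatter against two neighbours: 3-(trifluoromethyl)phenyl in place of 4-methylphenyl (a 3.2-fold lower number from compound 3 to compound 4 (0.50 log units; beyond the scatter)) and hydrogen in place of a second trifluoromethyl (a 2.5-fold lower number from compound 2 to compound 4 (0.40 log units; beyond the scatter)). Trifluoromethyl and chloro are not separated (a 1.3-fold lower number from compound 1 to compound 4 (0.11 log units; within the scatter)), so the two groups read alike here. No measurement at hand accounts for these steps.

Open, from the compounds shown here alone, is how a methoxy group, an amine or a carboxylic acid on this phenyl ring would read in this assay, and whether any of them would separate from compound 4.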